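A few compounds are considered here, and "the series" means these few. Any claim that something is new, unique, unknown or untested is made for them only; others in the source may bear on it.

Measured so far:
- compound 1 `CCNC(=O)C1=C(C)NC(=O)NC1c1ccsc1`, 3%
- compound 2 `CCN(CC)C(=O)C1=C(C)NC(=O)NC1c1ccsc1`, 11%
- compound 3 `CCC(CC)OC(=O)C1=C(C)NC(=O)NC1c1ccoc1`, 17%

All three were read in an assay on membranes from CHO cells for displacement of a labelled ligand from adenosine receptor A1 (Homo sapiens), read by scintillation counting, with a stated time of 60 min, tested at 1 uM; a lower number here means less inhibition, a higher number more inhibition at the concentration tested (going by the name of the read-out). Compound 3 gives the highest of the three numbers; compound 2 lies within the usual scatter of it, and only compound 1 lies beyond it. For the measured compounds named here, the one single-point step, a number 8 percentage points higher from compound 1 to compound 2 (within the scatter), concerns the amide-type nitrogen and stays within the scatter.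

Compound 4 `CCC(CC)OC(=O)C1=C(C)NC(=O)NC1c1ccsc1` is not yet measured. Against compound 3 the change is thiophen-3-yl in place of furan-3-yl on a saturated ring carbon. Going by the values given here, no measured pair isolates this exchange: compound 1 and compound 2 carry the thiophen-3-yl group but differ from compound 3 in the carbonyl-bearing group as well, so their values cannot be read as a step for the ring swap alone. Among the compounds with values here, the only quantified step bears on another part of the molecule and is small. No step beyond the scatter is therefore expected in this assay for this change. For compound 4 the value is estimated at 16%, with a range from 4% to 30%, which means an expected step of a number 1 percentage points lower from compound 3 to compound 4 (within the scatter).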

Compound 4, a percentage reported as inhibition, at one concentration (the size of the read-out at that concentration, not a potency): 22%
Estimate against measurement, compound 4: 6 percentage points below; measured number inside the range.
By their numbers in this assay, from the lowest: compounds 1, 2, 3 and 4 (each within the scatter of the next, the first and the last beyond it).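

In this assay the ring exchange on the saturated ring carbon is now isolated in one pair: thiophen-3-yl in place of furan-3-yl gives a number 5 percentage points higher from compound 3 to compound 4 (within the scatter) and so does not separate the two rings in this read-out. With thiophen-3-yl held constant, the group on the carbonyl carbon can also be read: (pentan-3-yl)oxy in place of diethylamino gives a number 11 percentage points higher from compound 2 to compound 4 (beyond the scatter) and (pentan-3-yl)oxy in place of ethylamino gives a number 19 percentage points higher from compound 1 to compound 4 (beyond the scatter) as the largest step in the series. Nothing measured here speaks to the reason for these steps.

Still open, going by these compounds, is whether a longer chain or a cyclohexyloxy group in place of (pentan-3-yl)oxy would carry this step further. Also open, on these data alone, is how a phenyl ring or an amine in place of thiophen-3-yl would read at this position.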